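Shifting the Chlorine: From Compound 1 to Compound 3

The source may hold more compounds than are shown below. What is called first, only, known or untested is meant among the compounds shown, and "the series" means these compounds.

Compound 1 `Cc1ccccc1Nc1nc(C)c(C(=O)/C=C/c2ccc(Cl)cc2)s1` gives > 25000 nM in a functional assay on NCI-H460 cells (Homo sapiens) for cytotoxicity, read by MTT assay; a higher number here means a weaker inhibitor, a lower number a stronger inhibitor. Compound 2 `Cc1nc(Nc2cccc(Cl)c2)sc1C(=O)/C=C/c1ccc(Cl)cc1` gives > 25000 nM in this assay.

Among the compounds with values here, compound 1 stands only at a limit of this assay: its value is a limit, not a number, and the one other value shown sits at the same limit (the limit of > 25000 nM in this assay, at which 2 of the 2 values shown sit). The step that the two limits leave unreadable from compound 1 to compound 2 is therefore unreadable, since both its ends are limits.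

Compound 3 `Cc1ccccc1Nc1nc(C)c(C(=O)/C=C/c2ccccc2Cl)s1` has not yet been measured. It differs from compound 1 in one place: 2-chlorophenyl in place of 4-chlorophenyl on a double-bonded chain carbon bound to a double-bonded chain carbon. Within the data shown here, no measured step bears on this change. Among the measured compounds shown here, the only step available, the exchange of 2-methylphenyl for 3-chlorophenyl on the nitrogen, touches a different part of the molecule and cannot be read in size or direction. So no step beyond the scatter can be predicted in either direction, and compound 3 is expected to remain at the limit like compound 1. Compound 3 is therefore estimated at 25000 nM, with an expected range of 8000 nM to 60000 nM. This estimate means an expected step of a number no higher from compound 1 to compound 3 (the limit leaves the size open) from compound 1.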

Compound 3, half-maximal inhibitory concentration: > 25000 nM
Compound 3 gave a limit, no number; the forecaster's own chance of this, stated with the estimate: 75%; the middle value sits exactly at the limit.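

In this assay compound 3 gives > 25000 nM, which is a limit and not a number. No step can be read between compound 1 and compound 3, as both stand at a limit: the limit of > 25000 nM in this assay, at which 3 of the 3 values shown sit. The compounds shown leave open what 2-chlorophenyl in place of 4-chlorophenyl does in this assay, and what value any of them would reach there.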